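Dithiolane-coumarin conjugates: methyl step on the ring

The source may report more compounds than this note shows. Statements on the series, on what has been measured and on what is new or still open speak of the compounds shown alone.

Measured so far in a functional assay on PC-12 cells (Rattus norvegicus) for cytotoxicity, read by MTT assay, with stated times of 3 h and 2 h, tested at 20 uM; on this read-out lower numbers stand for a weaker effect and higher numbers for a stronger effect at the one concentration tested:
compound 1, `O=C(CCCCC1CCSS1)NCc1cn(CCCOc2ccc3ccc(=O)oc3c2)nn1`, gives 42.2%
compound 2, `Cc1cc(=O)oc2cc(OCCCn3cc(CNC(=O)CCCCC4CCSS4)nn3)ccc12`, gives 74.3%
compound 3, `O=C(CCCCC1CCSS1)NCc1cn(CCCCCOc2ccc3ccc(=O)oc3c2)nn1`, gives 78.5%

Compounds 1 and 2 share one core and differ in a single place: methyl in place of hydrogen on an aromatic carbon. This change gives a number 32.1 percentage points higher from compound 1 to compound 2 (beyond the scatter). Compound 3 carries a longer linker between the triazole and the aryl ether; how its core differs from that of compound 1 is not broken down here, so of that pair only the two values can be compared, and compound 3 stands well above compound 1 in this assay. Compound 2 and compound 3 lie within the scatter of each other, so no order between them is claimed.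

Compound 4, `Cc1cc(=O)oc2cc(OCCCCCn3cc(CNC(=O)CCCCC4CCSS4)nn3)ccc12`, is not yet measured. It differs from compound 3 by methyl in place of hydrogen on an aromatic carbon, the same change as that from compound 1 to compound 2, occurring twice in this set.

The expected step from compound 3 to compound 4 is a number 7.5 percentage points higher from compound 3 to compound 4 (within the scatter), smaller than the earlier one because compound 3 already gives 78.5% and the read-out cannot rise far past full effect; the expectation rests on one pair only and is tentative. Compound 4 is estimated at 86%, with a range from 68% to 97%.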

Compound 4, a percentage reported as activity, at one concentration (the size of the read-out at that concentration, not a potency): 70.3%
The estimate for compound 4 lay 15.7 percentage points above the measured number, within the range that was stated.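

In this assay, methyl in place of hydrogen on an aromatic carbon gives a number 8.2 percentage points lower from compound 3 to compound 4 (within the scatter), so this pair supports no order between compound 3 and compound 4. Among the compounds shown here, the change therefore does not carry over as a fixed step between these two cores, and the size of its effect on one core cannot be read across to the other: the same change on two cores in this assay, a number 32.1 percentage points higher (beyond the scatter) from compound 1 to compound 2 and a number 8.2 percentage points lower (within the scatter) from compound 3 to compound 4, 40.3 percentage points apart, beyond the scatter of two such steps This shows only that the step depends on the core in these two pairs; it does not show why, it gives no rule for any further core, and, as each number comes from a single tested concentration, it says nothing about potency.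

The compounds shown leave open whether the large step from compound 1 to compound 2 is specific to methyl or would also appear with an ethyl group, a methoxy group or a carboxylic acid on the same aromatic carbon. They also leave open how the methyl step behaves on a longer chain between the triazole and the aryl ether, and so whether the two steps seen here are part of any trend with chain length.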